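The source may hold more compounds than are shown below. What is called first, only, known or untested is meant among the compounds shown, and "the series" means these compounds.

Measured compounds:
Compound 1 `O=C(OCc1ccccc1)N1CCN(C(=S)SCc2cn(Cc3ccc(F)cc3)nn2)CC1` – 17600 nM
Compound 3 `CC(C)(C)OC(=O)N1CCN(C(=S)SCc2cn(Cc3cc(=O)oc4cc(O)ccc34)nn2)CC1` – 4960 nM
Compound 2 `COc1cc(Cn2cc(CSC(=S)N3CCNCC3)nn2)cc(OC)c1OC` – "not determined" (no result reported)

In a functional assay on MGC-803 cells (Homo sapiens) for inhibition, read by MTT assay, with a stated time of 72 h (on this read-out lower numbers stand for stronger inhibition and higher numbers for weaker inhibition), compound 1 gives 17600 nM, the higher of the two numbers and so the weaker inhibitor shown. Compound 3 gives 4960 nM, and the gap between them lies beyond the usual scatter of repeated measurements. For compound 2 no number was reported in this assay. Compound 4 `O=C(OCc1ccccc1)N1CCN(C(=S)SCc2cn(Cc3ccccc3Cl)nn2)CC1` differs from compound 1 by 2-chlorophenyl in place of 4-fluorophenyl on a saturated chain carbon bound to an aromatic nitrogen. Going by the values given here, no measured pair shows what this change does, so its size is unknown here; the step expected is a 1.2-fold lower number from compound 1 to compound 4 (0.07 log units; within the scatter), not beyond the scatter, and the direction is taken as roughly neutral. Compound 4 is expected at 15000 nM, with a range from 6000 nM to 40000 nM.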

Compound 4, half-maximal inhibitory concentration: 15500 nM
Estimate against measurement, compound 4: 1.0-fold (0.01 log units) below; the measured number falls inside the stated range.
By their numbers in this assay, from the lowest: compound 3; then compounds 4 and 1 (each within the scatter of the next).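

In this assay, putting 2-chlorophenyl in place of 4-fluorophenyl on a saturated chain carbon bound to an aromatic nitrogen gives a 1.1-fold lower number from compound 1 to compound 4 (0.06 log units; within the scatter). This first measured pair at this position therefore shows no real change in the number, even though the halogen and its ring number both differ. No measurement at hand would explain this result.

Going by these compounds, whether the halogen and its ring number each matter alone stays open, since they changed together. Also open, on these data alone, is how a phenyl ring carrying an amine or a carboxylic acid would behave here.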